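Swapping butyl for chlorophenyl on an amide nitrogen

The source may report more compounds than this note shows. Statements on the series, on what has been measured and on what is new or still open speak of the compounds shown alone.

Measured compounds:
- compound 1, `Cc1ccc(N2C(=O)C/C(=C\c3cccc(C(=O)Nc4ccc(Cl)cc4)c3)C2=O)cc1`: > 100000 nM
- compound 2, `CCCCNC(=O)c1cccc(/C=C2\CC(=O)N(Cc3ccccc3)C2=O)c1`: > 100000 nM

Among the measured compounds shown here, both compounds share a core and differ in two places at once, so no single step between them can be read. In an ADME assay on SW480 cells (Homo sapiens) for cytotoxicity, read by MTT assay, with a stated time of 72 h (a lower number here means a stronger inhibitor, a higher number a weaker inhibitor), compound 1 reaches only a limit of the assay, > 100000 nM. In the same test compound 2 likewise gives only a limit, > 100000 nM. For the measured compounds named here, compound 2 therefore stands at the edge of what the test can report, not at a number, and the one other value shown sits at the same edge (the limit of > 100000 nM in this assay, at which 2 of the 2 values shown sit).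

Compound 3, `O=C(Nc1ccc(Cl)cc1)c1cccc(/C=C2\CC(=O)N(Cc3ccccc3)C2=O)c1`, has not been measured. It carries 4-chlorophenyl in place of butyl on an amide-type nitrogen. Going by the values given here, with no measured step to lean on, and with compound 1 and compound 2 both at the limit in this assay, no shift beyond the usual scatter is expected from compound 2 to compound 3, and the estimated step is a step that the limit leaves unreadable from compound 2 to compound 3. Compound 3 is expected to give about 150000 nM, within a range from 50000 nM to 500000 nM, most likely reported again only as a limit.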

Compound 3, half-maximal inhibitory concentration: > 100000 nM
Compound 3 gave a limit, no number; the forecaster's own chance of this, stated with the estimate: 80%; the middle value does not contradict the limit.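

In this assay, compound 3 gives only a limit, so neither its step from compound 2 nor its step from compound 1 can be read: the limit of > 100000 nM in this assay, at which 3 of the 3 values shown sit.

The compounds shown leave open whether exchanging butyl for 4-chlorophenyl, or 4-methylphenyl for benzyl, changes the result in this assay at all.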